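The source may hold more compounds than are shown below. What is called first, only, known or untested is meant among the compounds shown, and "the series" means these compounds.

Measured in an assay on isolated protein (urine) for inhibition of Myeloperoxidase (Homo sapiens), read by spectrophotometry; a higher number here means a weaker inhibitor, a lower number a stronger inhibitor:
compound 1 `COc1c2ccccc2nn1C(C)C` — 704 nM
compound 2 `CCCCn1nc2ccccc2c1OC` — 910 nM
compound 3 `CC(C)n1[nH]c2ccccc2c1=O` — 660 nM

Compound 4 `CCCCn1[nH]c2ccccc2c1=O` awaits measurement in this assay. It differs from compound 3 in one place: butyl in place of isopropyl on an aromatic nitrogen. The same kind of change, though not the same one, separates compound 1 from compound 2: butyl in place of isopropyl on an aromatic nitrogen; around that place the ring atom bearing the methoxy group is also present, which is not so in compound 3 or compound 4. That earlier step gave a 1.3-fold higher number from compound 1 to compound 2 (0.11 log units; within the scatter). How the core of compound 3 differs from the core of compound 1 is not broken down here, and the values of compound 3 and compound 1 lie within the scatter of each other. Because a 1.3-fold higher number from compound 1 to compound 2 (0.11 log units; within the scatter) stayed within the scatter, a comparably small step is expected here. Compound 4 is therefore expected to show a 1.3-fold higher number from compound 3 to compound 4 (0.11 log units; within the scatter). The estimate for compound 4 in this assay is 850 nM, with a likely range from 400 nM to 1800 nM.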

Compound 4, half-maximal inhibitory concentration: 792 nM
The estimate for compound 4 lay 1.1-fold (0.03 log units) above the measured number; the range from low to high includes it.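

In this assay butyl in place of isopropyl on an aromatic nitrogen gives a 1.2-fold higher number from compound 3 to compound 4 (0.08 log units; within the scatter) and so behaves on this core as it did on the core of compound 1, the two steps agreeing: the same change on two cores in this assay, a 1.3-fold higher number (0.11 log units; within the scatter) from compound 1 to compound 2 and a 1.2-fold higher number (0.08 log units; within the scatter) from compound 3 to compound 4, 1.1-fold (0.03 log units) apart, within the scatter of two such steps. On these two cores, then, the change carries over as a small step, and no influence of the core on it can be read. This does not show that the change is without effect in general, for two steps this small cannot separate a slight real shift from scatter, and they speak for these two cores alone.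

The compounds shown hold only isopropyl and butyl on that nitrogen. On these data alone, how a longer chain, a benzyl group or a chain ending in an amine would read there remains open.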